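The source may report more compounds than this note shows. Statements on the series, on what has been measured and on what is new or still open speak of the compounds shown alone.

Compound 1 `COc1cc(Cl)nc2n/c(=N/C(=O)c3c(-c4ccc(Cl)cc4Cl)noc3C)sn12` is measured in a functional assay on the whole organism for inhibition, with Brassica napus as the target, with a stated time of 72 h, tested at 100 mg/L (a lower number here means less inhibition of growth, a higher number more inhibition of growth at the concentration tested), at 70.8%. Among the three measured compounds it holds the highest number, yet its companions sit close: compound 3 `Cc1onc(-c2ccc(Cl)cc2Cl)c1C(=O)/N=c1/nc2nc(Cl)cc(C)n2s1` gives 70.2%, and compound 2 `COc1cc(C)nc(NC(=S)NC(=O)c2c(-c3ccc(Cl)cc3Cl)noc2C)n1` gives 69.3%, both within the scatter of compound 1. Compound 4 `COc1cc(C)nc2n/c(=N/C(=O)c3c(-c4ccc(Cl)cc4Cl)noc3C)sn12` is the one not yet measured. It differs from compound 1 in one place: methyl in place of chloro on an aromatic carbon. Among the compounds with values here, the only measured step of one change is a number 0.6 percentage points lower from compound 1 to compound 3 (within the scatter), a different swap on the same core that left the number essentially unchanged. Within the data shown here, no measured pair shows a chloro-for-methyl exchange at this position, so the expected step is estimated at a number 1.8 percentage points lower from compound 1 to compound 4 (within the scatter), within the scatter. Compound 4 is therefore expected to give 69%, between 58% and 78%.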

Compound 4, percent growth inhibition at one concentration: 80.6%
Estimate against measurement, compound 4: 11.6 percentage points below; the measured number lies above the stated range.
By their numbers in this assay, from the lowest: compounds 2, 3, 1 and 4 (each within the scatter of the next, the first and the last beyond it).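

In this assay, putting methyl in place of chloro on this aromatic carbon gives a number 9.8 percentage points higher from compound 1 to compound 4 (within the scatter). Within the data shown here, this is the first measured change at this position, and although the step is larger than a number 0.6 percentage points lower from compound 1 to compound 3 (within the scatter), it does not clearly separate the two groups, so chloro and methyl cannot be told apart here on this read-out. Nothing available explains the size of the step.

On these data alone, whether an amine, a carboxylic acid or a longer chain at this position would stay within the scatter remains open. So does how compound 1 and compound 4 would compare at other concentrations.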